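The source may hold more compounds than are shown below. What is called first, only, known or untested is meant among the compounds shown, and "the series" means these compounds.

Compound 1 `O=c1ccn(COCCO)c(=O)[nH]1` gives in a functional assay on L1210 cells (Mus musculus) for inhibition (on this read-out lower numbers stand for stronger inhibition and higher numbers for weaker inhibition), only a limit, > 1000 ug/mL. Compound 2 `Nc1ccn(COCCO)c(=O)n1` likewise gives in this assay only a limit, > 1000 ug/mL. Among the compounds with values here, compound 1 thus stands at the limit of > 1000 ug/mL in this assay, at which 2 of the 2 values shown sit, and no step between measured compounds is available. Compound 3 `O=c1[nH]c(=O)n(COCCO)cc1/C=C/Br` differs from compound 1 in one place: 2-bromoethenyl in place of hydrogen on an aromatic carbon. Within the data shown here, with no measured step to lean on, the direction of any change in this assay from compound 1 to compound 3 is uncertain; a move toward stronger inhibition is possible, but another result at the limit is about as likely. For compound 3 the estimate is 400 ug/mL, between 50 ug/mL and 1000 ug/mL. This corresponds to an expected step of an at least 2.5-fold lower number from compound 1 to compound 3 (0.39 log units; beyond the scatter).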

Compound 3, concentration for 50% inhibition: > 1000 ug/mL
Compound 3: no number, only a limit (the forecaster's own chance of this, stated with the estimate: 55%); middle value at least 2.5-fold (0.39 log units) from the limit.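

Within the data shown here, compound 1 and compound 3 both give only limits in this assay, so no step between them can be read: the limit of > 1000 ug/mL in this assay, at which 3 of the 3 values shown sit. The compounds shown leave open whether any change on the shared core gives a readable number in this assay.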